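Chloromethyl Amide Replacing Oxan-4-yl Carbonyl in Compound 1

The compounds below may be only part of what the source reports. "The series", "measured", "known", "first", "only" and "open" are said of these compounds alone.

Measured compounds in a functional assay on SU-DHL-6 cells (Homo sapiens) for antiproliferative activity, read by MTT assay; a higher number here means a weaker inhibitor, a lower number a stronger inhibitor:
compound 1 `COc1ncc(-c2ccc3ncnc(N[C@H]4CCCN(C(=O)C5CCOCC5)C4)c3c2)cc1C#N`: 150 nM
compound 2 `COc1ncc(-c2ccc3ncnc(N[C@H]4CCCN(C(=O)CCBr)C4)c3c2)cc1C#N`: 15 nM
compound 3 `COc1ncc(-c2ccc3ncnc(N[C@H]4CCCN(C(=O)C5CCN(C)CC5)C4)c3c2)cc1C#N`: 420 nM

Compound 1 holds the second highest of the three numbers. Its nearest neighbour is compound 3, reached by a 2.8-fold higher number from compound 1 to compound 3 (0.45 log units; beyond the scatter); its furthest is compound 2, reached by a 10-fold lower number from compound 1 to compound 2 (1.00 log units; beyond the scatter).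

Compound 4 `COc1ncc(-c2ccc3ncnc(N[C@H]4CCCN(C(=O)CCl)C4)c3c2)cc1C#N` differs from compound 1 by chloromethyl in place of oxan-4-yl on a carbonyl carbon. For the measured compounds named here, the step that bears on this is the one to compound 2, where another small haloalkyl chain replaced the same oxan-4-yl and gave a 10-fold lower number from compound 1 to compound 2 (1.00 log units; beyond the scatter); the opposite direction is seen in a 28-fold higher number from compound 2 to compound 3 (1.45 log units; beyond the scatter). A lowering of similar size, a 7.5-fold lower number from compound 1 to compound 4 (0.88 log units; beyond the scatter), is therefore expected for compound 4. Compound 4 is estimated at 20 nM, with a range from 6 nM to 70 nM.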

Compound 4, half-maximal inhibitory concentration: 380 nM
Compound 4: middle estimate off by 19-fold (1.28 log units), on the low side; measured number outside the range, above it.
By their numbers in this assay, from the lowest: compound 2; then compound 1; then compounds 4 and 3 (each within the scatter of the next).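

In this assay, a short halogen-bearing chain on the carbonyl carbon does not by itself give the lower number: chloromethyl stands on the opposite side of compound 1 from 2-bromoethyl (a 2.5-fold higher number from compound 1 to compound 4 (0.40 log units; beyond the scatter)), and the gap between the two chains is large (a 25-fold higher number from compound 2 to compound 4 (1.40 log units; beyond the scatter)). Chloromethyl and 1-methylpiperidin-4-yl cannot be told apart here (a 1.1-fold lower number from compound 3 to compound 4 (0.04 log units; within the scatter)). Nothing measured accounts for these differences.

The compounds shown leave open whether the low number of compound 2 follows the bromine or the longer chain. A 2-chloroethyl or bromomethyl group would separate the two.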